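This account rests on a few compounds, and the source may have more. Where it says the series, first, only, none or still open, it means among the compounds named here.

Compound 1 `CCCCCCCCC(CCO)n1cnc2c(Cl)nc(Cl)nc21` gives 24000 nM
Compound 2 `CCCCCCCCC(CCO)n1cnc2c(N)nc(Cl)nc21` gives 13100 nM

In a functional assay on SW480 cells (Homo sapiens) for antiproliferative activity, read by MTT assay, with a stated time of 48 h (a lower number here means a stronger inhibitor, a higher number a weaker inhibitor), compound 2 at 13100 nM lies within the usual scatter of compound 1 at 24000 nM and neither can be called the better one. Compound 3 `CCCCCCCCCCCC(CCO)n1cnc2c(N)nc(Cl)nc21` keeps the core of compound 2 and differs by propyl in place of hydrogen on a saturated chain carbon, nine bonds along the chain from an aromatic nitrogen in the chain. Among the compounds with values here, the only measured step (a 1.8-fold lower number from compound 1 to compound 2 (0.26 log units; within the scatter)) concerns amino in place of chloro on an aromatic carbon and leaves the chain untouched, so no measured step gives a size for this change. On the structural change alone, a loose guess in this assay is a modest expected move to a lower number (a 1.9-fold lower number from compound 2 to compound 3 (0.27 log units; within the scatter)). Compound 3 is estimated at 7000 nM with an expected range of 2500 nM to 18000 nM for now.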

Compound 3, half-maximal inhibitory concentration: 17800 nM
Compound 3: middle estimate off by 2.5-fold (0.41 log units), on the low side, within the range that was stated.
By their numbers in this assay, from the lowest: compounds 2, 3 and 1 (each within the scatter of the next).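

In this assay, within the data shown here, the first change to the chain, propyl in place of hydrogen on this saturated carbon, gives a 1.4-fold higher number from compound 2 to compound 3 (0.13 log units; within the scatter) and so stays within the scatter. At this size, then, extending the chain at this position leaves the number without a readable change, and neither compound 2 nor compound 3 can be called the better one. No other measurement bears on this result.

Going by these compounds, whether a much longer chain, a phenyl ring or a carboxylic acid in this place would give a step beyond the scatter remains open.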